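From fluoro to bromo on compound 1

The source may hold more compounds than are shown below. What is called first, only, known or untested is meant among the compounds shown, and "the series" means these compounds.

Compound 1 `O=C(O)c1ccc(C(=O)/C(=C\c2ccc(F)c([N+](=O)[O-])c2)SCc2ccc(Cl)cc2Cl)cc1` is measured in a functional assay on DU-145 cells (Homo sapiens) for inhibition, read by trypan blue exclusion, with a stated time of 96 h (on this read-out higher numbers stand for weaker inhibition of growth and lower numbers for stronger inhibition of growth), where compound 1 gives 1000 nM. Among the compounds with values here, its only measured neighbour is compound 2 `O=C(O)c1ccc(C(=O)/C(=C\c2ccc(F)c([N+](=O)[O-])c2)SCc2ccc(C(F)(F)F)cc2)cc1`, and compound 2 gives 1000 nM, which leaves the pair level. Within the data shown here, compound 3 `O=C(O)c1ccc(C(=O)/C(=C\c2ccc(Br)c([N+](=O)[O-])c2)SCc2ccc(Cl)cc2Cl)cc1` has no measurement yet. It departs from compound 1 in a single place, bromo in place of fluoro on an aromatic carbon, turning 4-fluoro-3-nitrophenyl into 4-bromo-3-nitrophenyl. Among the measured compounds shown here, the one measured step shows no change at the digits printed from compound 1 to compound 2 (within the scatter), but that change concerns the group on a saturated chain carbon bound to a sulfur. For the measured compounds named here, no measurement yet tests a change at the fluoro, so the evidence for a shift is absent and no change beyond the scatter is expected. The estimated step is no change at the digits printed from compound 1 to compound 3 (within the scatter). Compound 3 is expected to give 1000 nM, with an estimated range from 450 nM to 2200 nM.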

Compound 3, concentration for 50% growth inhibition: 1000 nM
Compound 3: middle estimate and measured number agree at the digits printed; low and high end bracket the measured number.
By their numbers in this assay, from the lowest: compounds 1, 2 and 3 (each within the scatter of the next).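

In this assay, bromo in place of fluoro on this aromatic carbon, ortho to a nitro group, gives no change at the digits printed from compound 1 to compound 3 (within the scatter), so the 4-fluoro-3-nitrophenyl and 4-bromo-3-nitrophenyl forms read alike. Within the data shown here, the earlier step touched only the group on a saturated chain carbon bound to a sulfur, so this is the only reading so far of a change at this position, and here one halogen can replace the other with no visible shift in growth inhibition. Nothing measured here bears on why the two forms read alike.

Going by these compounds, it remains open whether this carbon accepts groups other than halogens, such as an amine or a methoxy group, or simply a hydrogen. On these data alone, it also remains open whether bromo and fluoro would still read alike with the 4-(trifluoromethyl)phenyl group of compound 2 in place.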